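The source may report more compounds than this note shows. Statements on the series, on what has been measured and on what is new or still open speak of the compounds shown alone.

Compound 1 `Cc1ccc2[nH]c(=O)c(CN(Cc3ccc(F)cc3)Cc3cccc4ccccc34)cc2c1` shows a limit, > 5000 nM, in a toxicity assay on MDCK cells (Canis lupus familiaris) for cytotoxicity, read by crystal violet staining, with a stated time of 48 h; on this read-out higher numbers stand for lower toxicity in this test and lower numbers for higher toxicity in this test.
Compound 2 `Cc1ccc2[nH]c(=O)c(CN(Cc3ccc(OCC(=O)OC(C)(C)C)cc3)Cc3ccc(C(C)(C)C)cc3)cc2c1` shows a limit, > 10000 nM, in this assay.

Compound 2 thus sits at the upper limit of this assay, as recorded in the limit of > 10000 nM in this assay, at which 1 of the 2 values shown sits. Compound 1 likewise sits at a limit, recorded in the limit of > 5000 nM in this assay, at which 1 of the 2 values shown sits. Among the compounds with values here, neither value is a number, so no measured step exists between the two. Compound 3 `Cc1ccc2[nH]c(=O)c(CN(Cc3ccc(N(C)C)cc3)Cc3ccc(C(C)(C)C)cc3)cc2c1` differs from compound 2 by dimethylamino in place of (tert-butoxycarbonyl)methoxy on an aromatic carbon. With only limits available, the step of a number no higher from compound 2 to compound 3 (the limit leaves the size open) is expected to be none beyond the scatter. Compound 3 is therefore estimated at 10000 nM, within 3000 nM to 30000 nM, and most likely again reported as a limit.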

Compound 3, half-maximal cytotoxic concentration: > 5000 nM
Compound 3: only a limit was reported (the forecaster's own chance of this, stated with the estimate: 80%); the middle value is on the limit's open side.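

Within the data shown here, compound 2 and compound 3 are both recorded only as limits in this assay, so no step between them can be read. The compounds shown leave open whether dimethylamino in place of (tert-butoxycarbonyl)methoxy changes the half-maximal cytotoxic concentration at all.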